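The source may hold more compounds than are shown below. What is called first, only, known or untested is meant among the compounds shown, and "the series" means these compounds.

Of the compounds shown here, three with a shared core have been measured in a functional assay (trachea) with Rattus norvegicus as the target; a higher number here means a more potent compound, by a factor of ten per unit of this negative logarithm, a lower number a less potent compound. Compound 1 `CC1(C)C=C(n2ccccc2=O)c2cc(C(=O)c3ccccc3F)ccc2O1` gives 6.34. Compound 2 `CC1(C)C=C(n2ccccc2=O)c2cc(C(=N)NO)ccc2O1` gives 5.51. Compound 3 `CC1(C)C=C(n2ccccc2=O)c2cc(OCC(=O)c3ccc(F)cc3)ccc2O1` gives 4.77, the lowest of the three numbers; its nearest neighbour is compound 2, and compound 1 lies furthest from it. Compound 4 `CC1(C)C=C(n2ccccc2=O)c2cc(OS(=O)(=O)F)ccc2O1` is not yet measured. It differs from compound 3 in one place: fluorosulfonyl in place of ((4-fluorophenyl)carbonyl)methyl on an oxygen on an aromatic ring. Going by the values given here, only one measured step is comparable. There, a small group of four heavy atoms without a ring replaced a nine-atom group carrying a six-membered aromatic ring of carbon only, and the result was a number 0.83 log units lower from compound 1 to compound 2 (beyond the scatter). The change to compound 4 likewise swaps a group holding a six-membered aromatic ring of carbon only for a small fluorosulfonyl group, though on an oxygen on an aromatic ring rather than on an aromatic carbon. A modest loss is therefore expected, roughly a number 0.27 log units lower from compound 3 to compound 4 (within the scatter) in this assay. For compound 4 the estimate is 4.5, with a likely range from 3.9 to 5.1.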

Compound 4, logarithm of the reciprocal of the active concentration, log(1/C): 7.22
Beside the measured number, compound 4's estimate is 2.72 log units below it, and the stated range ends below it.
By their numbers in this assay, from the lowest: compound 3; then compound 2; then compound 1; then compound 4.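

In this assay, going by these compounds alone, a small group without a ring on this oxygen brings no loss: with fluorosulfonyl in place of ((4-fluorophenyl)carbonyl)methyl, the result is a number 2.45 log units higher from compound 3 to compound 4 (beyond the scatter), whereas the one earlier step to a smaller group went downward. A six-membered aromatic ring of carbon only is therefore not required here for a high number, as the ringless (fluorosulfonyl)oxy group gives a number 0.88 log units higher from compound 1 to compound 4 (beyond the scatter) against the (2-fluorophenyl)carbonyl group and a number 1.71 log units higher from compound 2 to compound 4 (beyond the scatter) against the other ringless group. No measurement is available that explains the size of these steps.

The compounds shown leave open whether this result belongs to fluorosulfonyl itself or would hold for any small group on this oxygen, such as methyl or methanesulfonyl. They also leave open what the fluorine contributes, which an amine on the sulfur in its place could test.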